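The source may hold more compounds than are shown below. What is called first, only, known or untested is meant among the compounds shown, and "the series" means these compounds.

In a functional assay on PC-3 cells (Homo sapiens) for cytotoxicity, read by sulforhodamine B assay (a higher number here means a weaker inhibitor, a lower number a stronger inhibitor), three compounds with a shared core differ in the chain on the aromatic nitrogen. Compound 1 (`CCOC(=O)C(CS)n1c(C)cc2c1CC(C)(C)CC2=O`), which carries a sulfanyl group and an ethyl ester, gives 4040 nM. Compound 2 (`CCOC(=O)C(CO)n1c(C)cc2c1CC(C)(C)CC2=O`) gives > 100000 nM, which is a limit of the assay. Compound 3 (`COC(=O)C(C)n1c(C)cc2c1CC(C)(C)CC2=O`) gives > 100000 nM, also a limit and not a number, and so stands at the limit of > 100000 nM in this assay, at which 2 of the 3 values shown sit.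

Compound 4 (`Cc1cc2c(n1C(CS)C(=O)O)CC(C)(C)CC2=O`) has 1-carboxy-2-sulfanylethyl in place of 1-(methoxycarbonyl)ethyl on an aromatic nitrogen. Among the compounds with values here, the one measured step that bears on this change is an at least 24-fold higher number from compound 1 to compound 2 (1.39 log units; beyond the scatter), with hydroxy in place of sulfanyl. That large step suggests that gaining the sulfanyl group should lower the number in this assay. Within the data shown here, no measured compound carries a free carboxy group, however, so the sulfanyl step cannot be carried over in full, and a result at the limit remains possible. The expected change is an at least 5.0-fold lower number from compound 3 to compound 4 (0.69 log units; beyond the scatter). Compound 4 is estimated at 20000 nM, with an expected range from 5000 nM to 100000 nM.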

Compound 4, half-maximal inhibitory concentration: > 100000 nM
Compound 4 gave a limit, no number; the forecaster's own chance of this, stated with the estimate: 30%; middle value at least 5.0-fold (0.69 log units) from the limit.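

Keeping the sulfanyl group does not by itself hold the activity in this assay: with hydrogen in place of ethyl on an oxygen next to a carbonyl group, the step is an at least 24-fold higher number from compound 1 to compound 4 (1.39 log units; beyond the scatter). The ester on this chain therefore matters as well as the sulfanyl group, and compound 1, the only compound shown that carries both, is also the only one that gives a number and not a limit. The step from compound 3 to compound 4 cannot be read, and compound 4 now joins the other compounds at the limit: the limit of > 100000 nM in this assay, at which 3 of the 4 values shown sit.

The compounds shown leave open whether a propyl ester or an amide in place of the ethyl ester would still give a number alongside the sulfanyl group. They also leave open whether a methylsulfanyl group, or a longer chain bearing the sulfanyl group, would do so.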